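This account rests on a few compounds, and the source may have more. Where it says the series, first, only, none or still open, it means among the compounds named here.

Measured in a functional assay on HCT-116 cells (Homo sapiens) for inhibition, read by MTT assay, with a stated time of 24 h, tested at 10 uM; a higher number here means more inhibition of growth at the concentration tested, a lower number less inhibition of growth:
compound 1 `N#Cc1ccc(-c2cnc3[nH]cc(-c4nnc(-c5ccc(F)cc5)o4)c(=O)c3c2)cc1`: 18.9%
compound 2 `CS(=O)(=O)c1ccc(-c2cnc3[nH]cc(-c4nnc(-c5ccncc5)o4)c(=O)c3c2)cc1`: 7.83%
compound 3 `O=c1c(-c2nnc(-c3ccc(F)cc3)o2)c[nH]c2ncc(-c3cccnc3)cc12`: 19.7%

Compound 2 stands lowest of the three numbers in this assay; its nearest neighbour is compound 1, higher by a margin beyond the scatter, and compound 3 lies further off, also beyond the scatter. Among the measured compounds shown here, the only single-point step among the measured compounds is a number 0.8 percentage points higher from compound 1 to compound 3 (within the scatter), a swap on the shared core at a place other than the one changed below.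

Compound 4 `Cc1cccc(-c2nnc(-c3c[nH]c4ncc(-c5ccc(S(C)(=O)=O)cc5)cc4c3=O)o2)c1` is obtained from compound 2 by 3-methylphenyl in place of pyridin-4-yl on an aromatic carbon. For the measured compounds named here, no measured pair differs at that place alone: compounds 1 and 3 share the same group there but differ from compound 2 on the core as well, so their higher values give only a loose pointer. Going by the values given here, the one measured step was within the scatter and sat elsewhere, so it says nothing about the size here. Since compounds 1 and 3 sit somewhat higher than compound 2, a modest rise in this assay is expected for compound 4, though the number could also stay within the scatter of compound 2. The estimate for compound 4 is 14% (range 4% to 26%). The expected step is a number 6.2 percentage points higher from compound 2 to compound 4 (within the scatter).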

Compound 4, percent growth inhibition at one concentration: 25.2%
The estimate for compound 4 lay 11.2 percentage points below the measured number; measured number inside the range.
By their numbers in this assay, from the lowest: compound 2; then compounds 1, 3 and 4 (each within the scatter of the next).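

In this assay, the group on the aromatic carbon of the five-membered ring with 2 nitrogen and 1 oxygen proves able to move the read-out: 3-methylphenyl in place of pyridin-4-yl gives a step beyond the scatter (a number 17.4 percentage points higher from compound 2 to compound 4 (beyond the scatter)). Among the compounds shown here, the only earlier single-place step, at another place on the shared core, stayed within the scatter (a number 0.8 percentage points higher from compound 1 to compound 3 (within the scatter)), so this is the first sign of a position that responds, resting on one pair. Nothing measured here accounts for the step.

The change removes a ring nitrogen and adds a methyl at once, and the two remain unseparated; plain phenyl at this place would divide them. On these data alone, whether 3-methoxyphenyl, 3-aminophenyl or a longer chain in place of the methyl carries the rise further remains open.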